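Swapping oxan-4-yl in compound 2

The source may hold more compounds than are shown below. What is called first, only, known or untested is meant among the compounds shown, and "the series" means these compounds.

Compound 1 `CC1(C)CCC(CN2CCN(c3ccc(C(=O)NS(=O)(=O)c4ccc(NCC5CCOCC5)c([N+](=O)[O-])c4)c(Oc4cnc5[nH]ccc5c4)c3)CC2)=C(c2ccc(Cl)cc2C(F)(F)F)C1`: 74 nM
Compound 2 `CC1(C)CCC(CN2CCN(c3ccc(C(=O)NS(=O)(=O)c4ccc(NCC5CCOCC5)c([N+](=O)[O-])c4)c(Oc4cnc5[nH]ccc5c4)c3)CC2)=C(c2ccc(C(F)(F)F)cc2)C1`: 6.2 nM
Compound 3 `CC1(C)CCC(CN2CCN(c3ccc(C(=O)NS(=O)(=O)c4ccc(NCC5CCOCC5)c([N+](=O)[O-])c4)c(Oc4cnc5[nH]ccc5c4)c3)CC2)=C(c2ccc(C(F)(F)F)c(Cl)c2)C1`: 81 nM

These numbers come from a functional assay on RS4-11 cells (Homo sapiens) for inhibition, read by CCK-8 assay, with a stated time of 72 h (on this read-out lower numbers stand for stronger inhibition and higher numbers for weaker inhibition), as measured. Compound 2 stands lowest of the three at 6.2 nM on this read-out. Both a 12-fold lower number from compound 1 to compound 2 (1.08 log units; beyond the scatter) and a 13-fold higher number from compound 2 to compound 3 (1.12 log units; beyond the scatter) are large steps, whereas a 1.1-fold higher number from compound 1 to compound 3 (0.04 log units; within the scatter) stays within the scatter.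

Compound 4 `CN1CCC(CNc2ccc(S(=O)(=O)NC(=O)c3ccc(N4CCN(CC5=C(c6ccc(C(F)(F)F)cc6)CC(C)(C)CC5)CC4)cc3Oc3cnc4[nH]ccc4c3)cc2[N+](=O)[O-])C1` differs from compound 2 in one place, with 1-methylpyrrolidin-3-yl in place of oxan-4-yl on a saturated chain carbon bound to a nitrogen on an aromatic ring is the full count of that change.

Among the measured compounds shown here, no measured step touches this place. All three concern the aryl group on the double-bonded ring carbon, so they set no size for this change. For the measured compounds named here, they show only that one change elsewhere can move the number a long way, as a 13-fold higher number from compound 2 to compound 3 (1.12 log units; beyond the scatter) does. With compound 2 already lowest at 6.2 nM among the three, a modest rise is the working expectation. An expected 2.4-fold higher number from compound 2 to compound 4 (0.38 log units; beyond the scatter) is the central case, well short of the large measured steps. The estimate for compound 4 is 15 nM within an expected range of 4 nM to 60 nM on this read-out.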

Compound 4, half-maximal inhibitory concentration: 8.3 nM
Compound 4: the middle estimate sits 1.8-fold (0.26 log units) above what was measured; measured number inside the range.
By their numbers in this assay, from the lowest: compounds 2 and 4 (each within the scatter of the next); then compounds 1 and 3 (each within the scatter of the next).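

In this assay, among the compounds shown here, a 1.3-fold higher number from compound 2 to compound 4 (0.13 log units; within the scatter) is the only reading at this position, and it lies within the scatter, so compound 2 and compound 4 cannot be ordered. On the saturated chain carbon bound to a nitrogen on an aromatic ring, the series therefore accepts either oxan-4-yl or 1-methylpyrrolidin-3-yl, which differ in ring size and hetero atom, and this contrasts with the aryl group on the double-bonded ring carbon, where a 13-fold higher number from compound 2 to compound 3 (1.12 log units; beyond the scatter) is a large step. No measurement at hand gives a reason for this result.

As far as these compounds go, a single pair cannot show how widely this position accepts other groups, so it remains open whether a primary amine, a carboxylic acid or a longer chain on the same saturated chain carbon would stay within the scatter of compound 2. From the compounds shown here alone, it also remains open whether the exchange of oxan-4-yl for 1-methylpyrrolidin-3-yl would give a similar result with the chlorinated aryl groups of compound 1 and compound 3.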